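The source may hold more compounds than are shown below. What is called first, only, known or untested is meant among the compounds shown, and "the series" means these compounds.

Compound 2 `COc1ccc(-c2csc(NC(=O)COc3ccc(C(=O)c4ccc(F)cc4)cc3C)n2)cc1` gives 5800 nM in a functional assay on Ehrlich cells (Mus musculus) for cytotoxicity, read by LDH release, with a stated time of 48 h; a higher number here means a weaker inhibitor, a lower number a stronger inhibitor. Compound 1 `COc1ccc(-c2csc(NC(=O)COc3ccc(C(=O)c4ccc(C)cc4)cc3C)n2)cc1` differs from compound 2 by methyl in place of fluoro on an aromatic carbon; in this assay compound 1 gives 20900 nM, so that a 3.6-fold higher number from compound 2 to compound 1 (0.56 log units; beyond the scatter). Compound 3 `Cc1cc(C(=O)c2ccccc2F)ccc1OCC(=O)Nc1nc(-c2ccccc2)cs1` rests on another core; the difference between the two cores is not broken down here. In this assay compound 3 gives 16900 nM. Compound 4 `Cc1cc(C(=O)c2ccccc2C)ccc1OCC(=O)Nc1nc(-c2ccccc2)cs1` is not yet measured; it differs from compound 3 by methyl in place of fluoro on an aromatic carbon. This is the same kind of change as that seen between the measured pair, but not the same: there the methyl stands para to a large group, here ortho to a large group. Because the measured pair showed a 3.6-fold higher number from compound 2 to compound 1 (0.56 log units; beyond the scatter), the step expected for compound 4 is a 2.7-fold higher number from compound 3 to compound 4 (0.43 log units; beyond the scatter), with the changed place leaving room for doubt. Compound 4 is estimated at 45000 nM, between 18000 nM and 110000 nM.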

Compound 4, half-maximal inhibitory concentration: 26400 nM
Compound 4: middle estimate off by 1.7-fold (0.23 log units), on the high side; low and high end bracket the measured number.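

In this assay, methyl in place of fluoro at the position ortho to a large group gives a 1.6-fold higher number from compound 3 to compound 4 (0.19 log units; within the scatter), so on this core the change cannot be told from no change. Set beside the earlier step, the change carries over from one core to the other without a difference that can be read: the same change on two cores in this assay, a 3.6-fold higher number (0.56 log units; beyond the scatter) from compound 2 to compound 1 and a 1.6-fold higher number (0.19 log units; within the scatter) from compound 3 to compound 4, 2.3-fold (0.36 log units) apart, within the scatter of two such steps This shows that the two steps are compatible, but with only two pairs it does not show that the change has a fixed size across the series, and core and place of the change vary together here.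

The compounds shown leave open how an amine or a nitrile would behave on that aromatic carbon. They also leave open whether the change would give the same step at one place on both cores.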